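Acylating the Amino Group in a Three-Compound Series

A few compounds are considered here, and "the series" means these few. Any claim that something is new, unique, unknown or untested is made for them only; others in the source may bear on it.

compound 1 `Nc1cccc(-c2cn3c(-c4ccc(Cl)cc4)csc3n2)c1`: 22000 nM
compound 2 `C=C(Br)C(=O)Nc1cccc(-c2cn3c(-c4ccccc4)csc3n2)c1`: 1300 nM
compound 3 `COc1ccc(-c2csc3nc(-c4cccc(N)c4)cn23)cc1`: 19000 nM

In a functional assay on L1210 cells (Mus musculus) for inhibition, read by cell counting, with a stated time of 2 days (a higher number here means a weaker inhibitor, a lower number a stronger inhibitor), compound 3 stands second highest of the three numbers; compound 1 lies nearest, the two being within the scatter, whereas compound 2 lies furthest, a gap beyond the scatter. Within the data shown here, the only measured single step, a 1.2-fold lower number from compound 1 to compound 3 (0.06 log units; within the scatter), concerns the methoxy-for-chloro exchange and does not touch the amino group. Compound 4 `C=C(Br)C(=O)Nc1cccc(-c2cn3c(-c4ccc(OC)cc4)csc3n2)c1` differs from compound 3 by (1-bromoethenyl)carbonyl in place of hydrogen on a nitrogen on an aromatic ring. Among the measured compounds shown here, no measured step carries exactly this change; compound 2 bears the same acyl group on an unsubstituted phenyl analogue and gives a much lower number than compound 3. Compound 4 is therefore expected to land well below compound 3, the step being estimated as a 13-fold lower number from compound 3 to compound 4 (1.10 log units; beyond the scatter). Compound 4 is estimated at 1500 nM, within 500 nM to 4500 nM.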

Compound 4, half-maximal inhibitory concentration: 200 nM
For compound 4 the middle estimate is 7.5-fold (0.88 log units) above the measured one, outside the stated range (below it).
By their numbers in this assay, from the lowest: compound 4; then compound 2; then compounds 3 and 1 (each within the scatter of the next).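

In this assay, among these compounds, amino to ((1-bromoethenyl)carbonyl)amino gives a 95-fold lower number from compound 3 to compound 4 (1.98 log units; beyond the scatter), the first measured step at this nitrogen, and it lies beyond the scatter. With that acyl group in place, the added methoxy group gives a 6.5-fold lower number from compound 2 to compound 4 (0.81 log units; beyond the scatter), so the aromatic substituent also counts in this acylated pair. No evidence bearing on the origin of these steps is available. What the compounds shown leave open is whether the bromine matters, as a plain acetyl group on the same nitrogen could show.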